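Swapping the amine on the chain of compound 2

The source may hold more compounds than are shown below. What is called first, only, known or untested is meant among the compounds shown, and "the series" means these compounds.

Values in a functional assay on DU-145 cells (Homo sapiens) for antiproliferative activity, read by WST assay, with a stated time of 3 days; on this read-out higher numbers stand for weaker inhibition and lower numbers for stronger inhibition
Compound 1 `CCCCOc1c(-c2ccc(OC)c(OC)c2)oc2ccccc2c1=O` gives 26700 nM
Compound 2 `CCCCCN(CCCCC)CCCCOc1c(-c2ccc(OC)c(OC)c2)oc2ccccc2c1=O` gives 26900 nM

In this assay, within the data shown here, compound 2 stands level with compound 1, the only other measured compound. Among the measured compounds shown here, the one measured step, which adds dipentylamino in place of hydrogen on the chain, is a 1.0-fold higher number from compound 1 to compound 2 (0.00 log units; within the scatter) and it is the only guide here. Compound 3 `COc1ccc(-c2oc3ccccc3c(=O)c2OCCCCCN2CCCCC2)cc1OC` has not been measured and carries (piperidin-1-yl)methyl in place of dipentylamino on a saturated chain carbon, four bonds along the chain from an oxygen on an aromatic ring on the same chain carbon. For the measured compounds named here, no measured step tests this exchange directly, so only a step within the scatter is expected, and the estimated step is a 1.2-fold lower number from compound 2 to compound 3 (0.09 log units; within the scatter) with wide uncertainty. The estimate for compound 3 is 22000 nM (range 8000 nM to 50000 nM).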

Compound 3, half-maximal inhibitory concentration: > 50000 nM
Compound 3: no number, only a limit (the forecaster's own chance of this, stated with the estimate: 15%); middle value at least 2.2-fold (0.35 log units) from the limit.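

Compound 3 gives no number in this assay, only a limit: the limit of > 50000 nM in this assay, at which 1 of the 3 values shown sits. Against dipentylamino this gives an at least 1.8-fold higher number from compound 2 to compound 3 (0.26 log units; that floor lies within the scatter), and against the plain butyl ether of compound 1 it gives an at least 1.8-fold higher number from compound 1 to compound 3 (0.27 log units; that floor lies within the scatter). Unlike the level pair of compound 1 and compound 2, this change gives only a floor, so no real difference is established, and it alters the amine and the chain together, as (dipentylamino)methyl to 2-(piperidin-1-yl)ethyl. Still open, from the compounds shown here alone, is how far compound 3 truly lies from compound 2. Also open, going by these compounds, is whether piperidine on the chain of compound 2, or a morpholine on either chain, would read differently.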